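Aryloxy exchange on the shared core: cytotoxicity notes

A few compounds are considered here, and "the series" means these few. Any claim that something is new, unique, unknown or untested is made for them only; others in the source may bear on it.

Compound 3 `Cc1cc(Br)c(Oc2nc(Nc3ccc(C#N)cc3)nc3ccccc23)c(Br)c1` gives 25000 nM in an ADME assay on MT4 cells (Homo sapiens) for cytotoxicity, read by MTT assay, with a stated time of 4 days (on this read-out lower numbers stand for higher toxicity in this test and higher numbers for lower toxicity in this test), the lowest of the two numbers shown. Compound 1 `N#Cc1ccc(Nc2nc(Oc3c(Cl)cc(Cl)cc3Cl)c3ccccc3n2)cc1` gives 56000 nM in this assay ; the step between the two is a 2.2-fold lower number from compound 1 to compound 3 (0.35 log units; beyond the scatter). Compound 2 `Cc1cc(C)c(Oc2nc(Nc3ccc(C#N)cc3)nc3ccccc23)c(C)c1` gives only a limit in this assay, > 34000 nM, see (the limit of > 34000 nM in this assay, at which 1 of the 3 values shown sits). The step of an at least 1.3-fold lower number from compound 2 to compound 3 (0.13 log units; that floor lies within the scatter) is therefore read only as a floor.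

Compound 4 `COc1cc(C#N)ccc1Oc1nc(Nc2ccc(C#N)cc2)nc2ccccc12` is not yet measured. Its change from compound 3: 4-cyano-2-methoxyphenyl in place of 2,6-dibromo-4-methylphenyl on an oxygen on an aromatic ring. Going by the values given here, no measured step exchanges halogen-bearing aryloxy groups for a 4-cyano-2-methoxyphenyl, and the two steps onto compound 3 were modest or unreadable, with all three values clustered high. The step of a 1.6-fold higher number from compound 3 to compound 4 (0.20 log units; within the scatter) is expected to stay near the scatter. Compound 4 is estimated at 40000 nM, within 15000 nM to 110000 nM.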

Compound 4, half-maximal cytotoxic concentration: >= 140000 nM
Compound 4: a limit, no number; the forecaster's own chance of this, stated with the estimate: 35%; middle value at least 3.5-fold (0.54 log units) away from the limit.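

Compound 4 gives only a limit in this assay: the limit of >= 140000 nM in this assay, at which 1 of the 4 values shown sits. Even so, this place on the oxygen is no longer flat, with an at least 5.6-fold higher number from compound 3 to compound 4 (0.74 log units; beyond the scatter) and an at least 2.5-fold higher number from compound 1 to compound 4 (0.39 log units; beyond the scatter), and 4-cyano-2-methoxyphenyl reads as less toxic in this test than either halogen-bearing aryloxy group. The step from compound 2 cannot be read, as both values are limits.

On these data alone, it remains open whether the nitrile or the methoxy group accounts for these steps. As far as these compounds go, how an amine or a carboxylic acid on this ring would read is also open.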